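The source may report more compounds than this note shows. Statements on the series, on what has been measured and on what is new or still open speak of the compounds shown alone.

Measured so far in a functional assay on MCF7 cells (Homo sapiens) for antiproliferative activity, read by MTT assay, with a stated time of 48 h; a lower number here means a stronger inhibitor, a higher number a weaker inhibitor:

Compound 1 `Cc1ccc2nc(Nc3nc(Nc4ccc(S(N)(=O)=O)cc4)ncc3C)sc2c1`; in this assay compound 1 gives > 50000 nM, which is a limit of the assay and not a number.
Compound 2 `Cc1cnc(Nc2ccc(S(N)(=O)=O)cc2)nc1Nc1nc2ccc(Cl)cc2s1`; in this assay compound 2 gives 8430 nM.
Compound 3 `Cc1ccc2nc(Nc3ccnc(Nc4ccc(S(C)(=O)=O)cc4)n3)sc2c1`; in this assay compound 3 gives > 50000 nM, which is again a limit and not a number.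

Compound 1 and compound 2 differ by one change, (chloro in place of methyl on an aromatic carbon), and this change gave an at least 5.9-fold lower number from compound 1 to compound 2 (0.77 log units; beyond the scatter). Compound 3 and compound 4 differ by the same change, (chloro in place of methyl on an aromatic carbon), the place being the same in both pairs. Compound 4 `CS(=O)(=O)c1ccc(Nc2nccc(Nc3nc4ccc(Cl)cc4s3)n2)cc1` is not yet measured. The difference between the core of compound 1 and the core of compound 3 is not broken down here. Because (the limit of > 50000 nM in this assay, at which 2 of the 3 values shown sit), the measured step from compound 1 to compound 2 gives only a floor for its size, so for compound 4 a step of about an at least 3.3-fold lower number from compound 3 to compound 4 (0.52 log units; beyond the scatter) is expected, resting on that earlier step. Compound 4 is therefore estimated at 15000 nM, between 4000 nM and 50000 nM.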

Compound 4, half-maximal inhibitory concentration: > 50000 nM
Compound 4: no number, only a limit (the forecaster's own chance of this, stated with the estimate: 35%); middle value at least 3.3-fold (0.52 log units) away from the limit.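

Compound 3 and compound 4 both give a limit and not a number, so the step between them cannot be read: the limit of > 50000 nM in this assay, at which 3 of the 4 values shown sit.

Going by these compounds, whether chloro in place of methyl changes the number on the core of compound 3, as it did on the core of compound 1, stays open.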